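A Bromophenyl Variant of Compound 3 at One Concentration

The source may hold more compounds than are shown below. What is called first, only, known or untested is meant among the compounds shown, and "the series" means these compounds.

Measured so far:
Compound 1 `C=CCc1ccc(OCc2cn(-c3ccccc3CO)nn2)c(O)c1`: 12.9%
Compound 2 `C#CCOc1ccc(CC=C)cc1O`: 11.8%
Compound 3 `C=CCc1ccc(OCc2cn(-c3cccc(C#N)c3)nn2)c(O)c1`: 21.2%

In a functional assay on SK-N-SH cells (Homo sapiens) for inhibition, read by MTT assay, with a stated time of 72 h, tested at 30 uM (on this read-out lower numbers stand for less inhibition of growth and higher numbers for more inhibition of growth at the one concentration tested), compound 3 gives the highest of the three numbers, yet neither gap reaches beyond the scatter: the step of a number 8.3 percentage points higher from compound 1 to compound 3 (within the scatter) is small, and compound 2 gives 11.8% against compound 3 with 21.2%, again within scatter. Compound 4 `C=CCc1ccc(OCc2cn(-c3ccc(Br)cc3)nn2)c(O)c1` is the next variant, with 4-bromophenyl in place of 3-cyanophenyl on an aromatic nitrogen. For the measured compounds named here, only one measured step bears on this change, the swap of the group on the aromatic nitrogen, a number 8.3 percentage points higher from compound 1 to compound 3 (within the scatter), which stayed within scatter. No step beyond the scatter is therefore expected, and the step of a number 3.2 percentage points lower from compound 3 to compound 4 (within the scatter) is the estimate that follows. Compound 4 is expected to give about 18%, within a range from 5% to 32%.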

Compound 4, percent growth inhibition at one concentration: 38.3%
Estimate against measurement, compound 4: 20.3 percentage points below; measured number outside the range, above it.
By their numbers in this assay, from the lowest: compounds 2, 1 and 3 (each within the scatter of the next); then compound 4.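

In this assay, the group on the aromatic nitrogen proves able to move the number beyond the scatter: 4-bromophenyl gives a number 17.1 percentage points higher from compound 3 to compound 4 (beyond the scatter), and a number 25.4 percentage points higher from compound 1 to compound 4 (beyond the scatter). Among the three aryl groups shown at this position, only 4-bromophenyl stands apart from the others. No measurement here explains this rise.

From the compounds shown here alone, whether the bromine or its place on the ring carries the step stays open, as 3-cyanophenyl and 4-bromophenyl differ in both. A chlorine atom or an amine in place of the bromine could help separate the two.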